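The source may report more compounds than this note shows. Statements on the series, on what has been measured and on what is new or still open speak of the compounds shown alone.

Measured compounds:

Compound 1, `CCOc1ccc(Br)cc1-c1cc(Nc2ccc(C#N)cc2)nc(N)n1`, gives 17 nM in an assay on Sf9 cells for inhibition of 1-acyl-sn-glycerol-3-phosphate acyltransferase beta (Homo sapiens); a higher number here means a weaker inhibitor, a lower number a stronger inhibitor.
Compound 2, `Cc1ccc(Cl)cc1-c1cc(Nc2ccc(C(F)(F)F)cc2)nc(N)n1`, gives 140 nM in this assay.

Of the two numbers, compound 1 has the lower one, and the gap to compound 2 lies beyond the scatter, so compound 1 is the stronger inhibitor of this pair. The unmeasured compound 3, `CCOc1ccc(Br)cc1-c1cc(Nc2ccccc2)nc(N)n1`, differs from compound 1 in one place: hydrogen in place of cyano on an aromatic carbon. For the measured compounds named here, no pair of measured compounds differs in this one place, so the size of the step has to be judged without a directly comparable case. The nitrile is taken to contribute to the binding seen for compound 1, and its loss is expected to weaken inhibition by a modest margin, somewhat beyond the scatter. The expected step is a 2.9-fold higher number from compound 1 to compound 3 (0.47 log units; beyond the scatter). Compound 3 is therefore estimated at 50 nM, with a range from 15 nM to 200 nM.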

Compound 3, half-maximal inhibitory concentration: 120 nM
Beside the measured number, compound 3's estimate is 2.4-fold (0.38 log units) below it, within the range that was stated.
By their numbers in this assay, from the lowest: compound 1; then compounds 3 and 2 (each within the scatter of the next).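

The change from 4-cyanophenyl to phenyl gives a 7.1-fold higher number from compound 1 to compound 3 (0.85 log units; beyond the scatter) in this assay, so this aromatic carbon, para to a large group, is not indifferent to what it carries. Removing just 2 heavy atoms, with 1 hydrogen-bond acceptor among them, is enough for a step beyond the scatter. Nothing shown here speaks to the cause of this step.

Going by these compounds, whether this step is particular to the nitrile stays open: a chlorine, a methoxy group, an amide or a carboxylic acid on the same carbon would help to settle it. On these data alone, compound 2 carries a trifluoromethyl group there but also differs elsewhere, so the effect of that group on the core of compound 1 remains open too.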